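The compounds below may be only part of what the source reports. "The series", "measured", "known", "first", "only" and "open" are said of these compounds alone.

The compounds here share one core and differ in the aromatic group on a sulfonyl sulfur. In a functional assay on HeLa cells (Homo sapiens) for cytotoxicity, read by sulforhodamine B assay (on this read-out higher numbers stand for weaker inhibition and lower numbers for stronger inhibition), compound 1 (`COc1ccc(S(=O)(=O)NC(C2=CC(=O)c3c(O)ccc(O)c3C2=O)C(C)C)c(OC)c1`) gives 2750 nM while compound 2 (`CC(C)C(NS(=O)(=O)c1ccc(F)cc1)C1=CC(=O)c2c(O)ccc(O)c2C1=O`) gives 6650 nM and compound 3 (`CC(C)C(NS(=O)(=O)c1ccc(Br)cc1)C1=CC(=O)c2c(O)ccc(O)c2C1=O`) gives 7650 nM as its result. Compound 3 therefore sits level with compound 2 at the top of these three numbers and furthest from compound 1.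

Compound 4 (`CC(C)C(NS(=O)(=O)c1cccc(Br)c1)C1=CC(=O)c2c(O)ccc(O)c2C1=O`) is still unmeasured. It has the same atoms as compound 3, joined differently, with 3-bromophenyl in place of 4-bromophenyl on a sulfonyl sulfur. Among the compounds with values here, no measured pair makes this exact change, so the guidance is indirect. Bromo in place of fluoro on an aromatic carbon gave a 1.2-fold higher number from compound 2 to compound 3 (0.06 log units; within the scatter) and so stayed within the scatter. Replacing the dimethoxyphenyl group gave modest steps, namely a 2.4-fold higher number from compound 1 to compound 2 (0.38 log units; beyond the scatter) and a 2.8-fold higher number from compound 1 to compound 3 (0.44 log units; beyond the scatter) in the other two pairs. Even those swaps of a whole group moved the number only modestly, so compound 4 is expected to show no step beyond the scatter in this assay and neither direction is favoured. The estimated change is a 1.1-fold lower number from compound 3 to compound 4 (0.04 log units; within the scatter) and it remains only an expectation. For compound 4 the estimated value is 7000 nM with an expected range from 3500 nM to 14000 nM until the measurement arrives.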

Compound 4, half-maximal inhibitory concentration: 860 nM
Estimate against measurement, compound 4: 8.1-fold (0.91 log units) above, outside the stated range (below it).
By their numbers in this assay, from the lowest: compound 4; then compound 1; then compounds 2 and 3 (each within the scatter of the next).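

In this assay, 3-bromophenyl in place of 4-bromophenyl on the sulfonyl sulfur keeps the same atoms but gives the largest step in this set (an 8.9-fold lower number from compound 3 to compound 4 (0.95 log units; beyond the scatter)), whereas bromo in place of fluoro at the earlier site stayed small (a 1.2-fold higher number from compound 2 to compound 3 (0.06 log units; within the scatter)). Among these compounds, then, where the bromine sits on the ring counts for far more than which of the two halogens is present, and a change that looks minor on paper can outweigh the swap of a whole group. Compound 4 also separates from the 4-fluorophenyl compound (a 7.7-fold lower number from compound 2 to compound 4 (0.89 log units; beyond the scatter)) and from the 2,4-dimethoxyphenyl compound (a 3.2-fold lower number from compound 1 to compound 4 (0.50 log units; beyond the scatter)), so it is now the most potent of the four, and nothing measured here explains why this one change has so large an effect.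

Going by these compounds, it remains open whether the low number belongs to bromo itself or would carry over to 3-fluorophenyl, 3-aminophenyl or 3-carboxyphenyl on the same sulfur. On these data alone, the isopropyl group also stays fixed throughout, so it is unknown whether the step would survive with a longer chain there.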